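A few compounds are considered here, and "the series" means these few. Any claim that something is new, unique, unknown or untested is made for them only; others in the source may bear on it.

Of the compounds shown here, three sharing one core have been read in a functional assay on HeLa cells (Homo sapiens) for cytotoxicity, read by MTT assay; a higher number here means a weaker inhibitor, a lower number a stronger inhibitor. Compound 1 (`CCCCC(O)CC(=O)O[C@H](CC=C(C)C)C1=CC(=O)c2c(O)ccc(O)c2C1=O`) gives 72200 nM, compound 2 (`CCCCC(CC(=O)O[C@H](CC=C(C)C)C1=CC(=O)c2c(O)ccc(O)c2C1=O)OC(C)=O`) gives 73500 nM and compound 3 (`CC[C@@](C)(O)CC(=O)O[C@H](CC=C(C)C)C1=CC(=O)c2c(O)ccc(O)c2C1=O`) gives 17900 nM. Compound 3 therefore has the lowest number of the three, and its steps to both others lie beyond the scatter.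

The next compound, compound 4 (`CC(C)=CC[C@@H](OC(=O)C1CCCOC1)C1=CC(=O)c2c(O)ccc(O)c2C1=O`), keeps the core and alters the group on a carbonyl carbon: oxan-3-yl in place of 2-hydroxy-2-methylbutyl, (oxan-3-yl in place of 2-hydroxy-2-methylbutyl on a carbonyl carbon). The entering group is a six-membered non-aromatic ring, whereas the leaving group has no ring.

Among the measured compounds shown here, three measured steps bear on this change. Acetyl in place of hydrogen on an oxygen gives a 1.0-fold higher number from compound 1 to compound 2 (0.01 log units; within the scatter), so that change stays within the scatter. Exchanging the chain gives a 4.0-fold lower number from compound 1 to compound 3 (0.61 log units; beyond the scatter) and a 4.1-fold lower number from compound 2 to compound 3 (0.61 log units; beyond the scatter), both modest. For the measured compounds named here, no measured compound carries a ring at this place, so the evidence is indirect. Since compound 3 at 17900 nM sits at the low end of the numbers seen, a modest move towards a higher number is expected in this assay, no larger than the chain steps. The expected step is a 2.0-fold higher number from compound 3 to compound 4 (0.29 log units; within the scatter). For compound 4 the estimated value is 35000 nM, with an expected range from 12000 nM to 90000 nM.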

Compound 4, half-maximal inhibitory concentration: 60500 nM
Estimate against measurement, compound 4: 1.7-fold (0.24 log units) below, within the range that was stated.
By their numbers in this assay, from the lowest: compound 3; then compounds 4, 1 and 2 (each within the scatter of the next).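

In this assay the oxan-3-yl ring on a carbonyl carbon does not keep the low number of the 2-hydroxy-2-methylbutyl chain, giving a 3.4-fold higher number from compound 3 to compound 4 (0.53 log units; beyond the scatter) as a modest step of about the same size as the earlier chain steps. Set against the two open chains, the same ring gives a 1.2-fold lower number from compound 1 to compound 4 (0.08 log units; within the scatter) and a 1.2-fold lower number from compound 2 to compound 4 (0.08 log units; within the scatter), so this first ring at the position reads alike with 2-hydroxyhexyl and 2-acetoxyhexyl, and among the four compounds only compound 3 stands apart, with its steps to all the others beyond the scatter. No measurement beyond these cytotoxicity numbers is available to explain the step.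

The compounds shown leave open whether the higher number of compound 4 goes with the ring itself or with the loss of the hydroxyl group of the 2-hydroxy-2-methylbutyl chain, since the change replaces both at once. An oxan-3-yl ring carrying a hydroxyl group, a 2-methoxy-2-methylbutyl chain or a piperidine ring at this place would separate these readings.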